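Replacing the imidazolyl pendant of compound 3

The source may hold more compounds than are shown below. What is called first, only, known or untested is meant among the compounds shown, and "the series" means these compounds.

The series shares one core. Compound 1 `CC(C(=O)NCc1ccc(C(F)(F)F)nc1-c1cccc(Cl)c1)c1ccc(NS(C)(=O)=O)c(F)c1`, compound 2 `CC(C(=O)NCc1ccc(C(F)(F)F)nc1-c1ccoc1)c1ccc(NS(C)(=O)=O)c(F)c1` and compound 3 `CC(C(=O)NCc1ccc(C(F)(F)F)nc1-n1ccnc1)c1ccc(NS(C)(=O)=O)c(F)c1` differ only in the group on an aromatic carbon next to the ring nitrogen. In an assay on CHO cells for antagonist activity at transient receptor potential cation channel subfamily V member 1 (Homo sapiens), read by FLIPR (a lower number here means a stronger inhibitor, a higher number a weaker inhibitor), compound 1 gives 0.5 nM, compound 2 gives 1.4 nM and compound 3 gives 36.1 nM. Compound 3 thus has the highest number of the three, separated from compound 2 by a 26-fold higher number from compound 2 to compound 3 (1.41 log units; beyond the scatter) and from compound 1 by a 72-fold higher number from compound 1 to compound 3 (1.86 log units; beyond the scatter). Between the two carbocycle-bearing compounds the step is smaller, a 2.8-fold higher number from compound 1 to compound 2 (0.45 log units; beyond the scatter).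

Compound 4 `CC(C(=O)NCc1ccc(C(F)(F)F)nc1CCc1ccc(F)cc1)c1ccc(NS(C)(=O)=O)c(F)c1` is not yet measured. It differs from compound 3 in one place: 2-(4-fluorophenyl)ethyl in place of 1H-imidazol-1-yl on an aromatic carbon. Among the compounds with values here, the steps that bear on it are those that introduced the 1H-imidazol-1-yl, a 72-fold higher number from compound 1 to compound 3 (1.86 log units; beyond the scatter) and a 26-fold higher number from compound 2 to compound 3 (1.41 log units; beyond the scatter), both large and both toward weaker inhibition. Within the data shown here, removing that group in favour of one holding a six-membered aromatic ring of carbon only is expected to reverse much of that, though no measured compound carries the ring on an ethyl link, so the exact size is uncertain. Compound 4 is therefore expected to show a lower number in this assay, a step of about an 18-fold lower number from compound 3 to compound 4 (1.26 log units; beyond the scatter), with an estimate of 2 nM and a range from 0.4 nM to 10 nM.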

Compound 4, inhibition constant: 1.8 nM
The estimate for compound 4 lay 1.1-fold (0.05 log units) above the measured number, and the stated range covers the measured number.
By their numbers in this assay, from the lowest: compound 1; then compounds 2 and 4 (each within the scatter of the next); then compound 3.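

In this assay, the position next to the ring nitrogen tolerates a six-membered aromatic ring of carbon only carried on an ethyl link, not just a ring attached directly: 2-(4-fluorophenyl)ethyl removes most of the loss seen with 1H-imidazol-1-yl (a 20-fold lower number from compound 3 to compound 4 (1.30 log units; beyond the scatter)) and stands level with furan-3-yl (a 1.3-fold higher number from compound 2 to compound 4 (0.11 log units; within the scatter)). The directly attached 3-chlorophenyl of compound 1 still gives the lowest number (a 3.6-fold higher number from compound 1 to compound 4 (0.56 log units; beyond the scatter)), so the flexible link does not match it here. No evidence is available to explain these steps.

Open, from the compounds shown here alone, is whether the ethyl link or the fluorine matters more, which a directly attached 4-fluorophenyl, an unsubstituted 2-phenylethyl or a longer propyl chain would separate. Also open, going by these compounds, is how 1H-imidazol-1-yl would read on the same ethyl link.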